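This account rests on a few compounds, and the source may have more. Where it says the series, first, only, none or still open, it means among the compounds named here.

In a functional assay on PC-3 cells (Homo sapiens) for cytotoxicity, read by MTT assay, with a stated time of 72 h (a higher number here means a weaker inhibitor, a lower number a stronger inhibitor), compound 1 `COc1ccc(/C=C/C(=O)Nc2cc3c(Nc4ccc(F)c(Cl)c4)ncnc3cc2OC)cc1` gives "not active" (no number reported), so it provides no number from which to measure a step. Compound 4 `COc1cc2ncnc(Nc3ccc(F)c(Cl)c3)c2cc1NC(=O)/C=C/c1ccc(C#N)cc1` differs from it in one place: cyano in place of methoxy on an aromatic carbon.

The closest evidence comes from two relatives. Compound 2 `O=C(/C=C/c1cc(Br)c(O)c(Br)c1)Nc1cc2c(Nc3ccc(F)c(Cl)c3)ncnc2cc1O[C@H]1CCOC1` gives 25500 nM, and compound 3 `COc1ccc(/C=C/C(=O)Nc2cc3c(Nc4ccc(F)c(Cl)c4)ncnc3cc2O[C@H]2CCOC2)c(OC)c1OC` gives 7670 nM. Exchanging one substituted phenyl group for another on the double-bonded chain gave a 3.3-fold lower number from compound 2 to compound 3 (0.52 log units; beyond the scatter), a modest step. Both relatives also differ from compound 1 elsewhere, and neither carries cyano, so this step is only a loose guide. Going by the values given here, no measured step tests the exchange of methoxy for cyano directly.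

Among the compounds with values here, with no number for compound 1, no size of step can be stated, although a move towards measurable but still weak activity is expected. Compound 4 is estimated at 20000 nM, with an expected range of 7000 nM to 60000 nM.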

Compound 4, half-maximal inhibitory concentration: "not active" (no number reported)
No number was reported for compound 4; there is nothing to compare the estimate with.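

In this assay neither compound 1 nor compound 4 has a number, so no step can be read for the exchange of methoxy for cyano, and no evidence bears on this result. As far as these compounds go, whether cyano in place of methoxy changes cytotoxicity at all remains open.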